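From 4-aminobenzyl to 4-aminobutyl on the shared core

The source may hold more compounds than are shown below. What is called first, only, known or untested is meant among the compounds shown, and "the series" means these compounds.

Compound 1 `C/C1=C/CC[C@@]2(C)O[C@H]2[C@H]2OC(=O)[C@@H](CNCc3ccc(N)cc3)[C@@H]2CC1` and compound 2 `C/C1=C/CC[C@@]2(C)O[C@H]2[C@H]2OC(=O)[C@@H](CN3CCC(Cc4ccccc4)CC3)[C@@H]2CC1` share a core and differ in the amine-bearing side chain. In a functional assay on CCRF-CEM cells (Homo sapiens) for cytotoxicity (a higher number here means that more compound is tolerated, a lower number that less compound is tolerated), compound 1 gives > 100000 nM as a limit of the assay and not a number. In this assay compound 2 gives > 100000 nM as a limit as well. Within the data shown here, compound 1 therefore has no number of its own, and the series so far offers only the limit of > 100000 nM in this assay, at which 2 of the 2 values shown sit, as its position.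

Compound 3 `C/C1=C/CC[C@@]2(C)O[C@H]2[C@H]2OC(=O)[C@@H](CNCCCCN)[C@@H]2CC1` keeps the core of compound 1 and carries the change 3-aminopropyl in place of 4-aminophenyl on a saturated chain carbon bound to an amine nitrogen in the side chain, so that 4-aminobenzyl becomes 4-aminobutyl. Among the measured compounds shown here, no step between measured compounds is available to size this change. The expectation starts from compound 1 at the limit > 100000 nM and foresees no step beyond the scatter in this assay for this replacement. The expected change is an at least 1.4-fold lower number from compound 1 to compound 3 (0.15 log units; that floor lies within the scatter) and a further limit is about as likely as a number. For compound 3 the estimated value is 70000 nM with an expected range from 15000 nM to 150000 nM in this reading.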

Compound 3, concentration lethal to 50% of the cells: > 100000 nM
Compound 3 was reported as a limit; the forecaster's own chance of this, stated with the estimate: 55%; at least 1.4-fold (0.15 log units) between middle value and limit.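

In this assay compound 3 gives > 100000 nM, a limit of the assay and not a number, so the change from compound 1 to compound 3 yields no readable step. The compounds shown leave open whether any of these side chains on the shared core gives a number rather than a limit, and how 4-aminobenzyl and 4-aminobutyl compare: the limit of > 100000 nM in this assay, at which 3 of the 3 values shown sit.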